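The compounds below may be only part of what the source reports. "The series", "measured", "known", "first", "only" and "open" are said of these compounds alone.

Compound 1 `O=C1/C(=C\c2ccc(O)cc2)S/C(=N/c2ccccc2)N1Cc1ccncc1`: 142000 nM
Compound 2 `O=C1/C(=C\c2ccc(Cl)cc2)S/C(=N/c2ccccc2)N1Cc1ccncc1`: 42300 nM
Compound 3 `CC(C)c1ccc(/C=C2/S/C(=N/c3ccccc3)N(Cc3ccncc3)C2=O)cc1`: 137000 nM

In an ADME assay on HEK293 cells (Homo sapiens) for cytotoxicity, read by MTT assay, with a stated time of 48 h (a lower number here means a stronger inhibitor, a higher number a weaker inhibitor), compound 3 gives 137000 nM. It sits level with the hydroxy analogue, a 1.0-fold lower number from compound 1 to compound 3 (0.02 log units; within the scatter), and clear of the chloro analogue, a 3.2-fold higher number from compound 2 to compound 3 (0.51 log units; beyond the scatter).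

Compound 4 `CCOc1cc(/C=C2/S/C(=N/c3ccccc3)N(Cc3ccncc3)C2=O)ccc1O` brings (3-ethoxy-4-hydroxyphenyl in place of 4-isopropylphenyl on a double-bonded chain carbon bound to a double-bonded ring carbon), that is, 3-ethoxy-4-hydroxyphenyl in place of 4-isopropylphenyl on a double-bonded chain carbon bound to a double-bonded ring carbon. For the measured compounds named here, no measured step covers an ethoxy. The closest evidence is the exchange of hydroxy for isopropyl, which stayed within the scatter. Going by the values given here, only chloro has moved the number so far, a 3.4-fold lower number from compound 1 to compound 2 (0.53 log units; beyond the scatter).

The expected result is a 1.1-fold lower number from compound 3 to compound 4 (0.06 log units; within the scatter), with no change beyond the scatter. For compound 4 the estimate is 120000 nM, with an expected range of 55000 nM to 250000 nM.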

Compound 4, half-maximal inhibitory concentration: 46500 nM
Estimate against measurement, compound 4: 2.6-fold (0.41 log units) above; measured number outside the range, below it.
By their numbers in this assay, from the lowest: compounds 2 and 4 (each within the scatter of the next); then compounds 3 and 1 (each within the scatter of the next).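

In this assay, ethoxy in place of hydrogen on an aromatic carbon gives the first change from adding a group rather than exchanging one (a 3.1-fold lower number from compound 1 to compound 4 (0.48 log units; beyond the scatter)). The 3-ethoxy-4-hydroxyphenyl group also separates from 4-isopropylphenyl (a 2.9-fold lower number from compound 3 to compound 4 (0.47 log units; beyond the scatter)) but stays level with 4-chlorophenyl (a 1.1-fold higher number from compound 2 to compound 4 (0.04 log units; within the scatter)), so a hydroxy-bearing ring at this position need not give a high number. No available measurement explains the ethoxy effect. Open, on these data alone, is whether ethoxy acts without the hydroxy, and whether propoxy or an amine in place of ethoxy would give a similar number.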